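This account rests on a few compounds, and the source may have more. Where it says the series, first, only, none or still open, it means among the compounds named here.

- Compound 1 `C/C=C/C(=O)OCC1=C[C@@H](O)[C@H](O)[C@H](F)C1=O` gives 164000 nM in a functional assay on A549 cells (Homo sapiens) for cytotoxicity, read by MTT assay; a lower number here means a stronger inhibitor, a higher number a weaker inhibitor.
- Compound 2 `C/C=C/C(=O)OCC1=C[C@H]2O[C@](C)(OC)[C@@](C)(OC)O[C@@H]2CC1=O` gives 32000 nM in this assay.

Of these two, compound 2 stands lower than compound 1, and that gap is beyond the usual scatter. Compound 3 `C/C=C/C(=O)OCC1=C[C@H]2O[C@](C)(OC)[C@@](C)(OC)O[C@@H]2[C@H](F)C1=O` differs from compound 2 by a single change: fluoro in place of hydrogen on a saturated ring carbon. Among the compounds with values here, no measured pair shows this change on its own, so its direction cannot be read from the measured compounds. The step from compound 2 to compound 3 is therefore expected to be small, no change at the digits printed from compound 2 to compound 3 (within the scatter), likely not beyond the scatter. Compound 3 is estimated at 32000 nM, in the range 9000 nM to 110000 nM.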

Compound 3, half-maximal inhibitory concentration: 31000 nM
For compound 3 the middle estimate is 1.0-fold (0.01 log units) above the measured one, and the stated range covers the measured number.
By their numbers in this assay, from the lowest: compounds 3 and 2 (each within the scatter of the next); then compound 1.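

In this assay, within the data shown here, the single change gives a 1.0-fold lower number from compound 2 to compound 3 (0.01 log units; within the scatter). Among these compounds, on this saturated ring carbon, with the rest of compound 2 held fixed, fluoro and hydrogen therefore give matching numbers, which no earlier pair could show. Nothing measured here explains this result.

As far as these compounds go, whether chloro, an amine or a longer chain on this carbon would also match hydrogen remains open. From the compounds shown here alone, compound 1 differs from compound 3 in more than one place, so whether this change would give the same result on the core of compound 1 also remains open.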